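Trifluoromethyl for Chloro on the Aniline Ring

The source may report more compounds than this note shows. Statements on the series, on what has been measured and on what is new or still open speak of the compounds shown alone.

Compound 1: `O=C(/C=C\Nc1ccc(C(F)(F)F)cc1)c1cn(-c2ccccc2)nc1-c1ccc(F)cc1`, > 50000 nM
Compound 2: `O=C(/C=C\Nc1ccc(Cl)cc1)c1cn(-c2ccccc2)nc1-c1ccc(Cl)cc1`, 4650 nM

Among the compounds with values here, in a functional assay on HT-29 cells (Homo sapiens) for antiproliferative activity, read by MTT assay, with a stated time of 48 h (on this read-out lower numbers stand for stronger inhibition and higher numbers for weaker inhibition), compound 2 gives 4650 nM, the only plain number measured here. Compound 1 gives > 50000 nM, a limit of the assay (the limit of > 50000 nM in this assay, at which 1 of the 2 values shown sits). Compound 3, `O=C(/C=C\Nc1ccc(C(F)(F)F)cc1)c1cn(-c2ccccc2)nc1-c1ccc(Cl)cc1`, differs from compound 2 by trifluoromethyl in place of chloro on an aromatic carbon. Within the data shown here, no measured pair shows this change on its own; compound 1 carries the same trifluoromethyl yet differs from compound 2 in two places. A weakening step beyond the scatter is expected for compound 3 a 4.3-fold higher number from compound 2 to compound 3 (0.63 log units; beyond the scatter). Compound 3 is expected to give 20000 nM, in the range 6000 nM to 60000 nM.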

Compound 3, half-maximal inhibitory concentration: > 50000 nM
Compound 3: only a limit was reported; the forecaster's own chance of this, stated with the estimate: 35%; middle value at least 2.5-fold (0.39 log units) from the limit.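

Taken alone, with the rest of the molecule unchanged, trifluoromethyl in place of chloro gives an at least 10-fold higher number from compound 2 to compound 3 (1.03 log units; beyond the scatter), so this single change is enough to lose most of the activity seen for compound 2. The earlier pair could not show this, since compound 1 differs from compound 2 in two places. The step between compound 1 and compound 3 cannot be read, and compound 3 gives only a limit of the assay, not a number: the limit of > 50000 nM in this assay, at which 2 of the 3 values shown sit.

As far as these compounds go, what remains open is how other groups at this place would behave, such as a methoxy group, a nitrile or an amine. Whether chloro is special here or simply one of several workable groups also stays unanswered.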